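The source may report more compounds than this note shows. Statements on the series, on what has been measured and on what is new or still open speak of the compounds shown alone.

Compound 1, `COc1cc(-c2cc3nccc(-c4cc(OC)c(OC)c(OC)c4)n3n2)cc(OC)c1OC`: in a functional assay on HeLa cells (Homo sapiens) for inhibition, read by CCK-8 assay, with a stated time of 48 h (a lower number here means a stronger inhibitor, a higher number a weaker inhibitor), compound 1 gives > 10000 nM, a limit of the assay rather than a number.
Compound 2, `COc1cc(-c2ccnc3cc(-c4ccc(C(F)(F)F)cc4)nn23)cc(OC)c1OC`: in this assay compound 2 gives 1840 nM.
Compound 3, `CCOC(=O)c1ccc(-c2cc3nccc(-c4cc(OC)c(OC)c(OC)c4)n3n2)cc1`: in this assay compound 3 gives > 10000 nM, again a limit and not a number.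

Going by the values given here, compound 2 therefore stands alone as the only numerical value in this set, since the other two results sit at the limit of > 10000 nM in this assay, at which 2 of the 3 values shown sit. Compound 4, `COc1ccc(-c2cc3nccc(-c4cc(OC)c(OC)c(OC)c4)n3n2)cc1F`, differs from compound 2 by 3-fluoro-4-methoxyphenyl in place of 4-(trifluoromethyl)phenyl on an aromatic carbon. Among the compounds with values here, one measured step bears on this change, because it alters the same aromatic carbon: an at least 5.4-fold higher number from compound 2 to compound 3 (0.73 log units; beyond the scatter). Compound 1, which carries a trimethoxyphenyl at that position, is a limit where compound 2 gives a number, so both departures from the 4-(trifluoromethyl)phenyl seen so far lead to weaker inhibition in this assay. The 3-fluoro-4-methoxyphenyl keeps one fluorine but brings a methoxy, as in compound 1, and a step toward a higher number, at least modest and possibly reaching the limit, is expected. Compound 4 is accordingly estimated at 6000 nM, with a range from 2000 nM to 20000 nM. This estimate corresponds to an expected 3.3-fold higher number from compound 2 to compound 4 (0.51 log units; beyond the scatter).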

Compound 4, half-maximal inhibitory concentration: 236 nM
Compound 4: the middle estimate sits 25-fold (1.41 log units) above what was measured; measured number below the stated range.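

Until now, the only step read at this aromatic carbon ran toward weaker inhibition, and 4-(trifluoromethyl)phenyl had looked like the best of the groups shown there; the change to 3-fluoro-4-methoxyphenyl instead brings a 7.8-fold lower number from compound 2 to compound 4 (0.89 log units; beyond the scatter) in this assay. The position therefore admits a replacement of the 4-(trifluoromethyl)phenyl that improves on it, and the outcome depends on which substituted phenyl stands there, not merely on whether the 4-(trifluoromethyl)phenyl is kept. Compound 2 and compound 4 are the only two of the set that give numbers, and the remaining results are limits of the assay rather than numbers: the limit of > 10000 nM in this assay, at which 2 of the 4 values shown sit.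

The compounds shown do not separate what the fluorine and the methoxy each contribute, since a phenyl carrying only a 4-methoxy group or only a 3-fluoro group is not among them. Also open, as far as these compounds go, is how a phenyl bearing an amine or a carboxylic acid at this position would read in this assay, and whether the gain seen with compound 4 would hold with such groups.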